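Dimethylamino on the thiocarbonyl carbon: compound 2 to compound 3

The source may report more compounds than this note shows. Statements on the series, on what has been measured and on what is new or still open speak of the compounds shown alone.

Measured in a functional assay on SGC-7901 cells (Homo sapiens) for antiproliferative activity, read by sulforhodamine B assay, with a stated time of 72 h; on this read-out higher numbers stand for weaker inhibition and lower numbers for stronger inhibition:
- Compound 1 `NC(=S)N/N=C/c1cc2cccnc2s1`: 100000 nM
- Compound 2 `NC(=S)N/N=C/c1nc2ccccc2s1`: > 100000 nM

Compound 2 stands at > 100000 nM, which is a limit of the assay and not a number.

Compound 3 `CN(C)C(=S)N/N=C/c1nc2ccccc2s1` differs from compound 2 by dimethylamino in place of amino on a thiocarbonyl carbon.

Among the compounds with values here, no measured step covers this change, so the expectation is loose. In this assay the expected step of an at least 10-fold lower number from compound 2 to compound 3 (1.00 log units; beyond the scatter) points towards stronger inhibition, though a second limit remains possible.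

Compound 3 is estimated at 10000 nM, with an expected range of 500 nM to 100000 nM.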

Compound 3, half-maximal inhibitory concentration: 830 nM
Compound 3: the middle estimate sits 12-fold (1.08 log units) above what was measured, and the stated range covers the measured number.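

In this assay the thiocarbonyl carbon emerges as a position where one substitution, dimethylamino in place of amino, shifts the read-out strongly (an at least 120-fold lower number from compound 2 to compound 3 (2.08 log units; beyond the scatter)). The value of compound 2 (> 100000 nM) is a limit of the assay and not a number. The full size of the step stays unknown because it starts from that limit: the limit of > 100000 nM in this assay, at which 1 of the 3 values shown sits.

As far as these compounds go, it remains open whether methylamino, or a ring amine such as morpholine, at the same carbon would give a similar shift. From the compounds shown here alone, whether dimethylamino acts likewise on the core of compound 1 also remains open.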